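A few compounds are considered here, and "the series" means these few. Any claim that something is new, unique, unknown or untested is made for them only; others in the source may bear on it.

Measured in a functional assay, with a stated time of 6 min; on this read-out higher numbers stand for weaker inhibition and lower numbers for stronger inhibition:

compound 1 `CCCCCCCCCCCCCCCCNCn1nc(-c2ccc3c(c2)OCCO3)oc1=S`: 22900 nM
compound 2 `Fc1cccc(F)c1NCn1nc(-c2ccc3c(c2)OCCO3)oc1=S`: 3320 nM
compound 3 `FC(F)(F)c1cc(NCn2nc(-c3ccc4c(c3)OCCO4)oc2=S)cc(C(F)(F)F)c1`: 9320 nM

On these three numbers compound 2 carries the lowest value; compound 3 and compound 1 sit beyond the scatter above it, and all three share the same core, differing only in the group on the amine nitrogen.

Compound 4 `S=c1oc(-c2ccc3c(c2)OCCO3)nn1CNc1ccc(Br)cc1Br` is not yet measured. It differs from compound 2 as follows: 2,4-dibromophenyl in place of 2,6-difluorophenyl on an amine nitrogen. For the measured compounds named here, no pair of measured compounds shows a step of this kind, so the size of the step is open. The two aryl-bearing compounds, compound 2 and compound 3, lie closer to each other than either does to compound 1, which suggests an aryl group keeps the value in that lower region.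

The expectation for compound 4 is a step of a 1.5-fold higher number from compound 2 to compound 4 (0.18 log units; within the scatter), at most modestly upward and possibly within the scatter. Compound 4 is thus estimated at 5000 nM, with a range from 1500 nM to 16000 nM.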

Compound 4, half-maximal inhibitory concentration: 6410 nM
The estimate for compound 4 lay 1.3-fold (0.11 log units) below the measured number, within the range that was stated.
By their numbers in this assay, from the lowest: compounds 2, 4 and 3 (each within the scatter of the next, the first and the last beyond it); then compound 1.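

In this assay, 2,4-dibromophenyl in place of 2,6-difluorophenyl on the amine nitrogen gives a 1.9-fold higher number from compound 2 to compound 4 (0.29 log units; within the scatter), so this exchange of both the halogen and its placement on the ring does not separate the two compounds. This position therefore accepts either halogenated phenyl without a reading beyond the scatter. No measurement on hand accounts for this result.

Halogen identity and placement change together in this step, so their separate contributions cannot be read. Also open, on these data alone, is where a plain phenyl or a butyl chain on the amine nitrogen would fall.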